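The compounds below may be only part of what the source reports. "The series", "measured", "known", "first", "only" and "open" are said of these compounds alone.

Measured so far in a functional assay on NCI-H1975 cells (Homo sapiens) for antiproliferative activity, read by MTT assay, with a stated time of 72 h; on this read-out higher numbers stand for weaker inhibition and lower numbers for stronger inhibition:
Compound 1, `COc1cc2ncnc(Nc3ccc(F)cc3)c2cc1OCCCCC(=O)Nc1ccc(S(N)(=O)=O)cc1`, gives > 40000 nM, a limit of this assay rather than a number.
Compound 2, `COc1cc2ncnc(Nc3ccc(Br)cc3)c2cc1OCCCCC(=O)Nc1ccc(S(N)(=O)=O)cc1`, gives 23300 nM.
Compound 3, `COc1cc2ncnc(Nc3ccc(OC(F)(F)F)cc3)c2cc1OCCCCC(=O)Nc1ccc(S(N)(=O)=O)cc1`, gives 8770 nM.

Compound 1 therefore stands only at a limit in this assay, and the line the limit of > 40000 nM in this assay, at which 1 of the 3 values shown sits, marks where it sits. Compound 4, `COc1cc2ncnc(Nc3ccc(C)cc3)c2cc1OCCCCC(=O)Nc1ccc(S(N)(=O)=O)cc1`, differs from it in one place: methyl in place of fluoro on an aromatic carbon. Two measured steps start from compound 1 and touch the same aromatic carbon. One is an at least 1.7-fold lower number from compound 1 to compound 2 (0.23 log units; that floor lies within the scatter), the other at least 4.5-fold lower number from compound 1 to compound 3 (0.65 log units; beyond the scatter); between those two compounds the step is a 2.7-fold lower number from compound 2 to compound 3 (0.42 log units; beyond the scatter). Both larger groups lowered the number, the trifluoromethoxy more than the bromo, though each step from compound 1 is only a floor because compound 1 itself is a limit. Methyl is a single-heavy-atom group like fluoro, and no measured compound carries it, so the account expects compound 4 to stay close to compound 1, with an at least 1.1-fold lower number from compound 1 to compound 4 (0.05 log units; that floor lies within the scatter), which lies within the scatter. The estimate for compound 4 in this assay is 35000 nM, with a range from 12000 nM to 100000 nM, and a fair chance that only a limit is reported.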

Compound 4, half-maximal inhibitory concentration: 19300 nM
Compound 4: middle estimate off by 1.8-fold (0.26 log units), on the high side; the range from low to high includes it.
By their numbers in this assay, from the lowest: compound 3; then compounds 4 and 2 (each within the scatter of the next). At a limit, above all of these: compound 1.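

In this assay, the swap of one heavy atom for another on this aromatic carbon, methyl in place of fluoro, gives an at least 2.0-fold lower number from compound 1 to compound 4 (0.31 log units; beyond the scatter), so the move away from fluoro lowers the number beyond the scatter with methyl as well as with trifluoromethoxy, and a group without a halogen can do this at this position. Methyl and bromo cannot be separated here, with a 1.2-fold lower number from compound 2 to compound 4 (0.08 log units; within the scatter), whereas trifluoromethoxy keeps a real margin over methyl, with a 2.2-fold higher number from compound 3 to compound 4 (0.34 log units; beyond the scatter). The step from fluoro to methyl is only a floor because compound 1 stands at a limit and not at a number: the limit of > 40000 nM in this assay, at which 1 of the 4 values shown sits.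

The compounds shown leave open how methoxy, trifluoromethyl or an amine on this same carbon would read, and so whether the oxygen or the fluorines of trifluoromethoxy go with the lower number of compound 3. From the compounds shown here alone, it also remains open whether a longer chain, or a carboxylic acid in place of the sulfonamide, would shift the whole series or change the order of these groups.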